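Thiazolyl hydrazone series: aryl variation on the thiazole

A few compounds are considered here, and "the series" means these few. Any claim that something is new, unique, unknown or untested is made for them only; others in the source may bear on it.

Measured so far in a functional assay on Caco-2 cells (Homo sapiens) for inhibition, read by MTT assay, with a stated time of 48 h; a higher number here means a weaker inhibitor, a lower number a stronger inhibitor:
compound 1 `COc1cc(/C=N/Nc2nc(-c3ccc(F)c(F)c3)cs2)c(Br)c(Br)c1OC` gives 22800 nM
compound 2 `COc1cc(/C=N/Nc2nc(-c3ccccc3)cs2)c(Br)c(Br)c1OC` gives 26500 nM
compound 3 `COc1ccccc1-c1csc(N/N=C/c2cc(OC)c(OC)c(Br)c2Br)n1` gives > 100000 nM, a limit of the assay rather than a number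

Among the compounds with values here, compound 3 is the one value sitting at the limit (the limit of > 100000 nM in this assay, at which 1 of the 3 values shown sits); compound 1 and compound 2 lie within the scatter of each other. The steps onto compound 3 are an at least 4.3-fold higher number from compound 1 to compound 3 (0.64 log units; beyond the scatter) and an at least 3.7-fold higher number from compound 2 to compound 3 (0.57 log units; beyond the scatter), both beyond the scatter.

Compound 4 `COc1cc(/C=N/Nc2nc(-c3cccc(Br)c3)cs2)c(Br)c(Br)c1OC` differs from compound 3 by 3-bromophenyl in place of 2-methoxyphenyl on an aromatic carbon. Both measured steps that end in compound 3 concern the 2-methoxyphenyl, and compound 4 drops it for a halogen-bearing phenyl, as compound 1 carries. The expected step is therefore an at least 3.3-fold lower number from compound 3 to compound 4 (0.52 log units; beyond the scatter), toward a lower number. Compound 4 is expected near 30000 nM, between 10000 nM and 100000 nM.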

Compound 4, half-maximal inhibitory concentration: > 100000 nM
Compound 4: a limit, no number (the forecaster's own chance of this, stated with the estimate: 20%); middle value at least 3.3-fold (0.52 log units) from the limit.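

In this assay, dropping the 2-methoxyphenyl does not bring back a measured value, so the loss at this position is not tied to that group alone: bromo in place of hydrogen gives an at least 3.7-fold higher number from compound 2 to compound 4 (0.57 log units; beyond the scatter), and 3-bromophenyl in place of 3,4-difluorophenyl gives an at least 4.3-fold higher number from compound 1 to compound 4 (0.64 log units; beyond the scatter). A halogen on this phenyl does not in itself keep a value, as the 3,4-difluorophenyl of compound 1 does and the 3-bromophenyl of compound 4 does not. The step between compound 3 and compound 4 cannot be read: the limit of > 100000 nM in this assay, at which 2 of the 4 values shown sit.

Any order between compound 3 and compound 4 stays open. So does whether an amine or a carboxylic acid on this phenyl would give a number.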